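Phenyl for methyl on the amide nitrogen: series notes

The compounds below may be only part of what the source reports. "The series", "measured", "known", "first", "only" and "open" are said of these compounds alone.

Measured so far:
compound 1, `O=C(Nc1ccccc1)c1cc2cc(-c3cccc(O)c3)ccc2cc1O`: 62%
compound 2, `CNC(=O)c1cc2cc(-c3cccc(O)c3)ccc2cc1O`: 18%
compound 3, `CNC(=O)/C=C/c1c(O)ccc2cc(-c3cccc(O)c3)ccc12`: 58%

All three numbers come from an in vitro assay on Sf9 cells for inhibition of 17-beta-hydroxysteroid dehydrogenase type 1 (Homo sapiens), tested at 1 uM; a lower number here means a weaker effect, a higher number a stronger effect of the compound at the concentration tested. Compound 2 is the only one of the three that sits low; in this assay compound 2 gives 18%, and compound 1 gives 62%. Within the data shown here, the single measured step, a number 44 percentage points higher from compound 2 to compound 1 (beyond the scatter), belongs to the change (phenyl in place of methyl on an amide-type nitrogen). Compound 3 stands close to compound 1: in this assay compound 3 gives 58%, and the two values lie within the scatter of each other, so no order between them is claimed. Compound 3 and compound 2 differ in their cores; that difference is not broken down here, and only their two values, far apart, can be compared.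

Compound 4, `O=C(/C=C/c1c(O)ccc2cc(-c3cccc(O)c3)ccc12)Nc1ccccc1`, is not yet measured. It differs from compound 3 by phenyl in place of methyl on an amide-type nitrogen, the same change as that from compound 2 to compound 1, at a place described in the same words, so it is taken as the same change. Among the measured compounds shown here, its one measured instance gave a large rise. For compound 4 a rise is expected as well, but a smaller one, because compound 3 already gives 58% and the read-out cannot climb far above it, so the step is estimated as a number 20 percentage points higher from compound 3 to compound 4 (beyond the scatter). Compound 4 is thus estimated at 78%, with a plausible range from 60% to 92%.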

Compound 4, a percentage reported as inhibition, at one concentration (the size of the read-out at that concentration, not a potency): 60%
The estimate for compound 4 lay 18 percentage points above the measured number; low and high end bracket the measured number.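

In this assay the replacement of methyl by phenyl on the amide-type nitrogen gives a number 2 percentage points higher from compound 3 to compound 4 (within the scatter), so on the core of compound 3 this change leaves no effect that can be told from the scatter. This does not show why the change behaves differently on the two cores, and two cores are too few to support any rule for a third, so the size of the step on one core cannot be taken as a guide to its size on another. The comparison does show that, in this series, the change cannot be carried from one core to the other at the same size: the same change on two cores in this assay, a number 44 percentage points higher (beyond the scatter) from compound 2 to compound 1 and a number 2 percentage points higher (within the scatter) from compound 3 to compound 4, 42 percentage points apart, beyond the scatter of two such steps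

The compounds shown leave open how other groups on the amide-type nitrogen, such as benzyl, a longer chain such as n-butyl or a chain ending in an amine, would behave on each of the two cores. They also leave open whether a phenyl carrying a carboxylic acid or a hydroxyl group would give a step on the core of compound 3 that can be told from the scatter.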